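A few compounds are considered here, and "the series" means these few. Any claim that something is new, unique, unknown or untested is made for them only; others in the source may bear on it.

Measured in a functional assay on MCF7 cells (Homo sapiens) for cytotoxicity, read by MTT assay, with a stated time of 72 h; on this read-out higher numbers stand for weaker inhibition and lower numbers for stronger inhibition:
compound 1 `CCC(C)=C1C(=O)N(c2ccc(Cl)cc2)N(c2ccc(Cl)cc2)C1=O`: 41600 nM
compound 2 `COc1cc(C=C2C(=O)N(c3ccc(Cl)cc3)N(c3ccc(Cl)cc3)C2=O)cc(OC)c1OC`: 16200 nM
compound 3 `COc1ccc(C=C2C(=O)N(c3ccc(Cl)cc3)N(c3ccc(Cl)cc3)C2=O)cc1`: > 128000 nM, a limit and not a number

The three compounds share one core and differ in what is attached to it through the double-bonded ring carbon. Compound 3 has no numerical value, and it stands at the limit of > 128000 nM in this assay, at which 1 of the 3 values shown sits. Compound 4 `O=C1C(=Cc2ccc(F)cc2F)C(=O)N(c2ccc(Cl)cc2)N1c1ccc(Cl)cc1` has not yet been measured. It carries 2,4-difluorophenyl in place of 4-methoxyphenyl on a double-bonded chain carbon bound to a double-bonded ring carbon.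

Within the data shown here, no pair of measured compounds differs in one place only, so the size of this change has no direct precedent. Among the measured compounds shown here, the only guide is the range of the numerical values in this assay, where compound 1 gives 41600 nM and compound 2 gives 16200 nM. On that basis, a step beyond the usual scatter toward stronger inhibition is expected, although compound 4 may also be reported only as a limit. The expected move is an at least 2.5-fold lower number from compound 3 to compound 4 (0.40 log units; beyond the scatter). For compound 4 the estimated value is 50000 nM, with an expected range from 14000 nM to 128000 nM.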

Compound 4, half-maximal inhibitory concentration: 22000 nM
Compound 4: the middle estimate sits 2.3-fold (0.36 log units) above what was measured; low and high end bracket the measured number.
By their numbers in this assay, from the lowest: compounds 2, 4 and 1 (each within the scatter of the next, the first and the last beyond it). At a limit, above all of these: compound 3.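

In this assay, placing 2,4-difluorophenyl in place of 4-methoxyphenyl on a double-bonded chain carbon bound to a double-bonded ring carbon gives an at least 5.8-fold lower number from compound 3 to compound 4 (0.76 log units; beyond the scatter). Among these compounds, this is the first step at this position that can be read at all, and it shows that the group carried there can decide whether the compound returns a number in this assay. Compound 3 stands at > 128000 nM, which is a limit and not a number. The real size of the step therefore stays unknown at its upper end, because it rests on that limit: the limit of > 128000 nM in this assay, at which 1 of the 4 values shown sits.

The compounds shown leave open whether the step goes with losing the methoxy group or with gaining the fluorine atoms, and the two changes arrive together in compound 4. They also leave open how a plain phenyl, or a phenyl ring bearing an amine or a carboxylic acid, would read at this position in this assay.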